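This account rests on a few compounds, and the source may have more. Where it says the series, first, only, none or still open, it means among the compounds named here.

Measured so far:
compound 1 `CCCS(=O)(=O)Nc1cccc2c1CCC2c1ncc[nH]1` — in a functional assay on CHO cells for agonist activity at Alpha-1D adrenergic receptor (Homo sapiens), read by FLIPR and calcium flux (on this read-out lower numbers stand for an effect already at smaller amounts and higher numbers for an effect only at larger amounts of compound), compound 1 gives only a limit, > 10000 nM
compound 2 `CS(=O)(=O)Nc1cccc2c1CCC2c1ncc[nH]1` — in this assay compound 2 gives only a limit, > 10000 nM

Going by the values given here, the one step between measured compounds, a step that the two limits leave unreadable from compound 1 to compound 2, cannot be read in either direction; this is summed up by the limit of > 10000 nM in this assay, at which 2 of the 2 values shown sit. Compound 2 thus stands at the limit of this assay without a number of its own.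

Compound 3 `Cn1cc(-c2cccc3c2CCC3c2ncc[nH]2)cn1` differs from compound 2 by 1-methyl-1H-pyrazol-4-yl in place of methanesulfonamido on an aromatic carbon. Among the compounds with values here, no measured step bears on this change in a readable way: the only step is unreadable, and no measured compound carries the entering group. With both known values sitting at the limit, nothing in the data fixes a direction or a size for this change, and the estimated step is a step that the limit leaves unreadable from compound 2 to compound 3, so compound 3 is expected to stay near the limit. Compound 3 is estimated at 15000 nM, with a range from 2000 nM to 100000 nM, and a limit report remains the more likely outcome.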

Compound 3, half-maximal effective concentration: > 10000 nM
Compound 3: no number, only a limit; the forecaster's own chance of this, stated with the estimate: 70%; the middle value lies beyond the limit too.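

Compound 3 gives > 10000 nM, a limit and not a number, and its steps from compound 1 and compound 2 cannot be read. The series so far rests on one reading: the limit of > 10000 nM in this assay, at which 3 of the 3 values shown sit.

Still open, on these data alone, is whether any substituent on this aromatic carbon gives a measurable effect in this assay.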